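The source may hold more compounds than are shown below. What is called first, only, known or untested is meant among the compounds shown, and "the series" means these compounds.

Measured so far:
- compound 1, `COc1ccc(S(=O)(=O)N2CCc3cccc(-c4ccc(F)nc4)c32)cc1`: 151 nM
- compound 2, `COc1ccc(S(=O)(=O)N2CCc3cccc(-c4ccco4)c32)cc1`: 79.2 nM

For the measured compounds named here, in a functional assay on KB-VIN10 cells (Homo sapiens) for inhibition, with a stated time of 72 h (on this read-out lower numbers stand for stronger inhibition and higher numbers for weaker inhibition), compound 1 has the highest of the two numbers; the only measured step, a 1.9-fold lower number from compound 1 to compound 2 (0.28 log units; within the scatter), stays within the scatter. Compound 3, `COc1ccc(S(=O)(=O)N2CCc3cccc(-c4ccccc4)c32)cc1`, differs from compound 1 by phenyl in place of 6-fluoropyridin-3-yl on an aromatic carbon. Going by the values given here, no measured step swaps in phenyl at this position; the one step that bears on a change there is small, so no step beyond the scatter is expected in this assay. Compound 3 is therefore estimated at 110 nM, with a range of 50 nM to 250 nM, which means an expected step of a 1.4-fold lower number from compound 1 to compound 3 (0.14 log units; within the scatter).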

Compound 3, half-maximal inhibitory concentration: 107 nM
Compound 3: middle estimate off by 1.0-fold (0.01 log units), on the high side; measured number inside the range.
By their numbers in this assay, from the lowest: compounds 2, 3 and 1 (each within the scatter of the next).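

Swapping 6-fluoropyridin-3-yl for phenyl (a 1.4-fold lower number from compound 1 to compound 3 (0.15 log units; within the scatter)) and furan-2-yl for phenyl (a 1.4-fold higher number from compound 2 to compound 3 (0.13 log units; within the scatter)) leaves this assay within the scatter both times. Removing the ring nitrogen and the fluorine together therefore produces no change these numbers can resolve, and a carbon-only six-membered aromatic ring fits this position as well as the two rings with a hetero atom. Nothing measured here gives a reason for this result.

All three compounds carry an aromatic ring at this position. On these data alone, whether an amine, a carboxylic acid or a longer chain there would give a step beyond the scatter remains open.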